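This account rests on a few compounds, and the source may have more. Where it says the series, first, only, none or still open, it means among the compounds named here.

Compound 1 `CC(C(=O)NCc1ccccc1Cl)N1C(=O)CCC1=O`: 74.5 mg/kg
Compound 2 `CCC(C(=O)NCc1ccccc1Cl)N1C(=O)CCC1=O`: 113 mg/kg

In a functional assay on the whole organism (strain Albino Swiss CD1) with Mus musculus as the target, in the maximal electroshock model (a lower number here means that less compound is needed, a higher number that more compound is needed for the effect), compound 1 holds the lower of the two numbers, although the gap to compound 2, a 1.5-fold higher number from compound 1 to compound 2 (0.18 log units; within the scatter), does not exceed the scatter. Compound 3 `CC1CC(=O)N(C(C)C(=O)NCc2ccccc2Cl)C1=O` differs from compound 1 by methyl in place of hydrogen on a saturated ring carbon, placed two ring bonds from the ring nitrogen. Among the measured compounds shown here, the only measured step that bears on this is the addition of a methyl elsewhere, a 1.5-fold higher number from compound 1 to compound 2 (0.18 log units; within the scatter), so no step beyond the scatter is expected in this assay. For compound 3 the expected value is 85 mg/kg, within 45 mg/kg to 170 mg/kg, an expected step of a 1.1-fold higher number from compound 1 to compound 3 (0.06 log units; within the scatter).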

Compound 3, dose for half-maximal effect: 85.9 mg/kg
Compound 3: middle estimate off by 1.0-fold (0.00 log units), on the low side, and the stated range covers the measured number.
By their numbers in this assay, from the lowest: compounds 1, 3 and 2 (each within the scatter of the next).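

In this assay, methyl in place of hydrogen on a saturated ring carbon, two ring bonds from the ring nitrogen, gives a 1.2-fold higher number from compound 1 to compound 3 (0.06 log units; within the scatter) and so shows that the ring, and not only the chain, can carry this small addition without a step beyond the scatter. Nothing measured here explains this result.
Going by these compounds, what remains open is whether this ring carbon would accept more than a methyl. A longer chain, a phenyl ring or an amine in its place could give a different number.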